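This account rests on a few compounds, and the source may have more. Where it says the series, first, only, none or still open, it means among the compounds named here.

The measured compounds:

Compound 1, `COc1ccc(C2N=C(SCc3ccccc3)NC(C)=C2C(=O)Nc2ccc(F)cc2)cc1OC`, gives 6.2% in a functional assay on the whole organism (artery, strain albino) with Rattus norvegicus as the target, with a stated time of 60 min, at a dose of 10 mg/kg by the oral route; on this read-out higher numbers stand for more inhibition at the one dose given (going by the name of the read-out) and lower numbers for less inhibition.
Compound 2, `COc1ccc(C2N=C(SCc3ccc(Cl)cc3)NC(C)=C2C(=O)Nc2ccc(F)cc2)cc1OC`, gives 10.3%.
Compound 3, `CC1=C(C(=O)Nc2ccc(Br)cc2)C(c2ccc(Cl)cc2Cl)N=C(SCc2ccccc2)N1`, gives 6.7%.

All three compounds share the same core, and all three sit at low inhibition in this assay, with the three values lying within the usual scatter of one another. Within the data shown here, the one pair that differs in a single place is compound 1 and compound 2: chloro in place of hydrogen on an aromatic carbon. The step this made is a number 4.1 percentage points higher from compound 1 to compound 2 (within the scatter), so it cannot be told apart from repeat measurement noise.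

Compound 3 carries a different core, with other groups on the amide side and on the ring attached to the central ring; the difference between the two cores is not broken down here.

Compound 4, `CC1=C(C(=O)Nc2ccc(Br)cc2)C(c2ccc(Cl)cc2Cl)N=C(SCc2ccccc2Cl)N1`, has not yet been measured. It differs from compound 3 as follows: chloro in place of hydrogen on an aromatic carbon. Among the measured compounds shown here, this is the same kind of change as the one from compound 1 to compound 2, but not the same change: in compound 2 the chloro sits para to a large group, whereas in compound 4 it sits ortho to a large group. For the measured compounds named here, the step from compound 3 to compound 4 is expected to be a number 2.3 percentage points higher from compound 3 to compound 4 (within the scatter), an expectation that rests on the single comparable step, because a number 4.1 percentage points higher from compound 1 to compound 2 (within the scatter) lies within the scatter. Going by the values given here, with only one such step to go on, and it placed differently, the uncertainty is wide. Compound 4 is estimated at 9%, with a likely range from 0% to 22%.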

Compound 4, a percentage reported as inhibition, in the whole organism at one dose (the size of the read-out at that dose, not a potency): 11.8%
Compound 4: the middle estimate sits 2.8 percentage points below what was measured, within the range that was stated.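

In this assay, putting chloro in place of hydrogen on the benzyl group, ortho to a large group, gives a step of a number 5.1 percentage points higher from compound 3 to compound 4 (within the scatter), so on its own this step cannot be told apart from repeat measurement. Set beside the same change on the core of compound 1, the two steps agree: the same change on two cores in this assay, a number 4.1 percentage points higher (within the scatter) from compound 1 to compound 2 and a number 5.1 percentage points higher (within the scatter) from compound 3 to compound 4, 1 percentage points apart, within the scatter of two such steps

This shows that, in these two pairs, the core made no visible difference to what the chloro did, so the earlier step was a fair guide to the new one. Among these compounds, it does not show that chloro truly increases inhibition, since each step lies within the scatter, and with only two pairs, with the chloro placed differently in each, it cannot establish a rule for the wider series.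

The compounds shown leave open whether any change on this part of the molecule can move the inhibition beyond the scatter at the one dose given. An amine or a carboxylic acid on the benzyl ring, or a longer chain in place of the benzyl group on the sulfur, would be a much larger change than a single chloro and could begin to answer that.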